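From a Dimethyl Group to a Cyclopropane Ring

The source may hold more compounds than are shown below. What is called first, only, known or untested is meant among the compounds shown, and "the series" means these compounds.

In an assay on isolated protein for inhibition of histone deacetylase 4 (Homo sapiens), tested at 1 uM (on this read-out lower numbers stand for less inhibition and higher numbers for more inhibition at the one concentration tested (going by the name of the read-out)), compound 1 `CC(C)(C(=O)Nc1ccc(C(=O)Nc2ccc(F)cc2N)cc1)c1ccccc1` gives 0%. Compound 3 `CC(C)[C@H](C(=O)Nc1ccc(C(=O)Nc2ccccc2N)cc1)c1ccccc1` gives 0%, and compound 2 `CC(C)(C(=O)Nc1ccc(C(=O)Nc2ccccc2N)cc1)c1ccccc1` gives 6%. Compound 1 stands level with compound 3 at the digits shown, the two together at the bottom of the three numbers; its furthest neighbour is compound 2, and even that gap, a number 6 percentage points higher from compound 1 to compound 2 (within the scatter), stays within the scatter. That step is the only measured one between two compounds differing in a single place, and it concerns a fluoro on an aromatic ring, not the part that changes here.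

Compound 4 `Nc1cc(F)ccc1NC(=O)c1ccc(NC(=O)C2CC2c2ccccc2)cc1` differs from compound 1 in one place: 2-phenylcyclopropyl in place of 1-methyl-1-phenylethyl on a carbonyl carbon. For the measured compounds named here, no measured step touches the group on this carbonyl carbon. Going by the values given here, compound 3 carries yet another group there and also lacks the fluoro, and its value and that of compound 1 show only that both numbers lie at the floor of the read-out. Among the compounds with values here, with every number so far near that floor and no step beyond the scatter, the expected step of a number 2 percentage points higher from compound 1 to compound 4 (within the scatter) is none beyond the scatter. Compound 4 is therefore estimated at 2% in this assay, with a range from -8% to 12%.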

Compound 4, a percentage reported as inhibition, at one concentration (the size of the read-out at that concentration, not a potency): 0%
For compound 4 the middle estimate is 2 percentage points above the measured one; the range from low to high includes it.
By their numbers in this assay, from the lowest: compounds 1, 3, 4 and 2 (each within the scatter of the next).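

In this assay, the group on this carbonyl carbon now has its first measured step, and it reads no change at the digits printed from compound 1 to compound 4 (within the scatter) with 2-phenylcyclopropyl in place of 1-methyl-1-phenylethyl. The two groups have the same count of heavy atoms and both hold a six-membered aromatic ring, but the entering group adds a three-membered ring, and this difference leaves the number at the floor of the read-out. With both compounds at that floor and only one concentration tested, the step cannot separate two groups that truly perform alike from two groups that both fall short of a readable level, and nothing available explains the result.

What the shown compounds leave open is whether any group at this place can raise the number in this assay, since all of those shown carry a phenyl ring in this group, and an amine, a carboxylic acid or a longer alkyl chain on the same carbonyl carbon could read differently. Also open, going by these compounds, is whether 2-phenylcyclopropyl would read the same on the core of compound 4 with hydrogen in place of the fluoro.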